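A few compounds are considered here, and "the series" means these few. Any claim that something is new, unique, unknown or untested is made for them only; others in the source may bear on it.

Measured in a functional assay on A549 cells (Homo sapiens) for inhibition, read by MTT assay, with a stated time of 24 h; on this read-out lower numbers stand for stronger inhibition and higher numbers for weaker inhibition:
- compound 1 `CC1(C)[C@H]2CC[C@]1(C)N(Cc1cn(-c3ccc(O)cc3)nn1)C(=O)C2`: 140 nM
- compound 2 `CC1(C)[C@H]2CC[C@]1(C)N(Cc1cn(-c3ccc(Br)cc3)nn1)C(=O)C2`: 80 nM
- compound 3 `CC1(C)[C@H]2CC[C@]1(C)N(Cc1cn(-c3ccccc3O)nn1)C(=O)C2`: 230 nM

Of these three values, that of compound 3 is matched within the scatter by one other: a 1.6-fold higher number from compound 1 to compound 3 (0.22 log units; within the scatter). The remaining gap, a 2.9-fold higher number from compound 2 to compound 3 (0.46 log units; beyond the scatter), lies beyond the scatter but is modest.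

The next structure, compound 4 `CC1(C)[C@H]2CC[C@]1(C)N(Cc1cn(-c3ccc(Cl)cc3)nn1)C(=O)C2`, has not yet been measured. It differs by 4-chlorophenyl in place of 2-hydroxyphenyl on an aromatic nitrogen, with 4-chlorophenyl in place of 2-hydroxyphenyl on an aromatic nitrogen. Among the compounds with values here, no chloro compound has a value yet, so the closest guide is compound 2, which carries 4-bromophenyl at that place. Its gap to compound 3 suggests a modest move toward lower numbers in this assay. The step of a 1.8-fold lower number from compound 1 to compound 2 (0.24 log units; within the scatter) stays within the scatter and adds only weak support. The step expected is a 2.6-fold lower number from compound 3 to compound 4 (0.41 log units; beyond the scatter). Compound 4 is estimated at 90 nM, with an expected range of 45 nM to 180 nM.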

Compound 4, half-maximal inhibitory concentration: 70 nM
Estimate against measurement, compound 4: 1.3-fold (0.11 log units) above; low and high end bracket the measured number.
By their numbers in this assay, from the lowest: compounds 4, 2, 1 and 3 (each within the scatter of the next, the first and the last beyond it).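

In this assay, replacing 2-hydroxyphenyl with 4-chlorophenyl on the aromatic nitrogen gives a 3.3-fold lower number from compound 3 to compound 4 (0.52 log units; beyond the scatter) and so places a second halogen compound beyond the scatter from compound 3, as compound 2 already was. Chloro and bromo are not told apart at this place, as a 1.1-fold lower number from compound 2 to compound 4 (0.06 log units; within the scatter) shows. Chloro in place of hydroxy gives a 2.0-fold lower number from compound 1 to compound 4 (0.30 log units; within the scatter) and so leaves compound 1 unseparated from each of the other three compounds, which means that only compound 3 stands apart, and only from the two halogen compounds.

On these data alone, whether 2-chlorophenyl would read with the halogen compounds or with compound 3 stays open, as does the reading of an amine or a carboxylic acid on the phenyl ring. Nothing given here accounts for these differences.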